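A few compounds are considered here, and "the series" means these few. Any claim that something is new, unique, unknown or untested is made for them only; others in the source may bear on it.

Compound 1 `CC(=O)OCc1ccc2oc(=O)c(C(=O)Oc3cccc(Br)c3)cc2c1` gives 21.8% in a functional assay on HT-1080 cells (Homo sapiens), read by transwell migration, with a stated time of 24 h, tested at 1 uM; a higher number here means a weaker effect of the compound at the concentration tested, a lower number a stronger effect. Compound 2 `CCC(=O)OCc1ccc2oc(=O)c(C(=O)Oc3cccc(Br)c3)cc2c1` gives 40.2%. Compound 3 `CCCC(=O)OCc1ccc2oc(=O)c(C(=O)Oc3cccc(Br)c3)cc2c1` gives 50.5%.

Compound 3 stands highest of the three numbers, and both a number 10.3 percentage points higher from compound 2 to compound 3 (beyond the scatter) and a number 28.7 percentage points higher from compound 1 to compound 3 (beyond the scatter) lie beyond the scatter. Compound 4 `CCCCC(=O)OCc1ccc2oc(=O)c(C(=O)Oc3cccc(Br)c3)cc2c1` carries the next change in the same series: methyl in place of hydrogen on a saturated chain carbon, three bonds along the chain from a carbonyl carbon. Two earlier steps each added one methyl to the chain in this way: a number 18.4 percentage points higher from compound 1 to compound 2 (beyond the scatter) and a number 10.3 percentage points higher from compound 2 to compound 3 (beyond the scatter), the second smaller than the first. A further rise is therefore expected, probably smaller again, which is what a number 6.5 percentage points higher from compound 3 to compound 4 (within the scatter) means. Compound 4 is estimated to give 57% in this assay, with a range from 45% to 70%.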

Compound 4, a percentage reported as activity, at one concentration (the size of the read-out at that concentration, not a potency): 63.3%
Estimate against measurement, compound 4: 6.3 percentage points below; low and high end bracket the measured number.
By their numbers in this assay, from the lowest: compound 1; then compound 2; then compound 3; then compound 4.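

Among these compounds, one more methyl at this far point of the chain still weakens the effect, a number 12.8 percentage points higher from compound 3 to compound 4 (beyond the scatter), so the climb continues past compound 3 and adds up to a number 23.1 percentage points higher from compound 2 to compound 4 (beyond the scatter) and the one large step, a number 41.5 percentage points higher from compound 1 to compound 4 (beyond the scatter). Across these four compounds each added methyl raises the number, and none goes against this. A methyl added here counts about as much as the first one added to the chain: the same change on two cores in this assay, a number 18.4 percentage points higher (beyond the scatter) from compound 1 to compound 2 and a number 12.8 percentage points higher (beyond the scatter) from compound 3 to compound 4, 5.6 percentage points apart, within the scatter of two such steps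

On these data alone, whether a longer chain would raise the number further or level off remains open. So does the effect of an amine or a carboxylic acid at the chain end.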